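The source may hold more compounds than are shown below. What is called first, only, known or untested is meant among the compounds shown, and "the series" means these compounds.

Compound 1 `CCOC(=O)c1ccc(OCc2cc(OC)c(OC)c(OC)c2)cc1` in a physicochemical assay, with a stated time of 30 min (on this read-out higher numbers stand for weaker inhibition and lower numbers for stronger inhibition), gives > 100 ug/mL, which is a limit of the assay and not a number. Compound 2 `CCOc1cc(/C=N/NC(=O)c2ccc(OCc3cc(OC)c(OC)c(OC)c3)cc2)ccc1O` in this assay gives 106 ug/mL. Compound 3 `COc1cc(COc2ccc(C(=O)N/N=C/c3ccc(OC)c(OC)c3OC)cc2)cc(OC)c1OC` in this assay gives > 100 ug/mL, again a limit rather than a number. The step that the limit leaves unreadable from compound 2 to compound 3 is therefore not readable, as the limit of > 100 ug/mL in this assay, at which 2 of the 3 values shown sit, shows. Compound 4 `COc1cc(COc2ccc(C(=O)N/N=C/c3cccc(O)c3)cc2)cc(OC)c1OC` differs from compound 3 by 3-hydroxyphenyl in place of 2,3,4-trimethoxyphenyl on a carbon with a double bond to nitrogen. For the measured compounds named here, no measured step involves a 3-hydroxyphenyl group, so none bears directly on this change; compound 2, which carries a 3-ethoxy-4-hydroxyphenyl group at the same place, gave 106 ug/mL. Compound 4 is therefore expected to lie near 110 ug/mL, between 60 ug/mL and 200 ug/mL. The expected step that the limit leaves unreadable from compound 3 to compound 4 is none beyond the scatter.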

Compound 4, half-maximal inhibitory concentration: > 100 ug/mL
Compound 4: a limit, no number (the forecaster's own chance of this, stated with the estimate: 65%); the middle value does not contradict the limit.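

For the compounds shown here, the result for compound 4 in this assay is a limit and not a number, so no step linking it to compound 1, compound 2 or compound 3 can be read: the limit of > 100 ug/mL in this assay, at which 3 of the 4 values shown sit. The compounds shown leave open whether 3-hydroxyphenyl and 2,3,4-trimethoxyphenyl differ at all in this read-out.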